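The source may hold more compounds than are shown below. What is called first, only, known or untested is meant among the compounds shown, and "the series" means these compounds.

Measured so far:
compound 1 `CCSC(=S)SCC(=O)c1ccccc1` gives 5010 nM in the series
compound 2 `CCSC(=S)SCC(=O)c1ccccc1OC` gives 15800 nM in the series
compound 3 `CCOC(=O)Nc1cccc(C(=O)CSC(=S)SCC)c1` gives 2000 nM in the series

In a functional assay on HeLa cells (Homo sapiens) for antiproliferative activity, read by resazurin assay (on this read-out lower numbers stand for stronger inhibition and higher numbers for weaker inhibition), compound 1 at 5010 nM stands second highest of the three numbers, so it sits in the middle of the series. Compound 4 `CCSC(=S)SCC(=O)c1ccc(N(CC)CC)cc1` has not yet been measured. The change from compound 1 is diethylamino in place of hydrogen on an aromatic carbon and in words it is diethylamino in place of hydrogen on an aromatic carbon, para to a group of 9 heavy atoms.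

For the measured compounds named here, two measured steps bear on this. Methoxy in place of hydrogen on an aromatic carbon gave a 3.2-fold higher number from compound 1 to compound 2 (0.50 log units; beyond the scatter) and (ethoxycarbonyl)amino in place of hydrogen on an aromatic carbon gave a 2.5-fold lower number from compound 1 to compound 3 (0.40 log units; beyond the scatter) as the second case. Both are modest and beyond the scatter, and they run in opposite directions. Neither brings in diethylamino, so the data do not fix the direction. Compound 3 is the closer guide, since its entering group is also attached through nitrogen. In this assay a small step toward a lower number is therefore expected, no larger than those two and possibly within the scatter. The expected step is a 1.6-fold lower number from compound 1 to compound 4 (0.19 log units; within the scatter) on this reasoning. The estimated value for compound 4 is 3200 nM with an expected range from 1000 nM to 10000 nM as the working figure.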

Compound 4, half-maximal inhibitory concentration: 3160 nM
Compound 4: the middle estimate sits 1.0-fold (0.01 log units) above what was measured, and the stated range covers the measured number.
By their numbers in this assay, from the lowest: compounds 3, 4 and 1 (each within the scatter of the next, the first and the last beyond it); then compound 2.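

In this assay, diethylamino in place of hydrogen on an aromatic carbon, para to a group of 9 heavy atoms, gives a 1.6-fold lower number from compound 1 to compound 4 (0.20 log units; within the scatter) and so is not separated from compound 1 by this read-out. At this place on the ring, a group of 5 heavy atoms with no ring, no hydrogen-bond donors and no net charge therefore costs no activity beyond the scatter, whereas a 3.2-fold higher number from compound 1 to compound 2 (0.50 log units; beyond the scatter) and a 2.5-fold lower number from compound 1 to compound 3 (0.40 log units; beyond the scatter) each lie beyond it. No measurement on the compounds shown explains this outcome.

With diethylamino as the only group shown at this place, the compounds do not tell whether the result is specific to that group or extends to other substituents there, such as a primary amine, a carboxylic acid or a longer chain on the nitrogen. They also leave open whether methoxy or (ethoxycarbonyl)amino would keep the steps seen in compound 2 and compound 3 if either stood para to the group of 9 heavy atoms.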